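Swapping the Halogenated Bicycle on an Enol-Lactone Series

A few compounds are considered here, and "the series" means these few. Any claim that something is new, unique, unknown or untested is made for them only; others in the source may bear on it.

Measured compounds:
- compound 1 `O=C1NC(O)(/C=C\n2cc(I)c3c(Cl)ncnc32)C(OCc2ccccc2)=C1OCc1ccccc1`: > 250000 nM
- compound 2 `O=C1O/C(=C\Cn2cnc3c(Cl)c(F)nc(F)c32)C(OCc2ccccc2)=C1OCc1ccccc1`: "not determined" (no result reported)
- compound 3 `O=C1NC(O)(CCn2cnc3cncc(Br)c32)C(OCc2ccccc2)=C1OCc1ccccc1`: 50000 nM

In a functional assay on L1210/0 cells (Mus musculus) for antiproliferative activity, read by MTT assay, with a stated time of 72 h (on this read-out lower numbers stand for stronger inhibition and higher numbers for weaker inhibition), compound 1 gives > 250000 nM; this is a limit of the assay, not a number. In this assay, within the data shown here, compound 3 gives 50000 nM, the only plain number in the set. Compound 2 stands without any value in this assay, so its place among the others cannot be fixed, and the one limit recorded is the limit of > 250000 nM in this assay, at which 1 of the 3 values shown sits.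

Compound 4 `O=C1O/C(=C\Cn2cnc3ncc(Br)c-3c2)C(OCc2ccccc2)=C1OCc1ccccc1` keeps the enol-lactone core of compound 2 and its two benzyloxy groups; the change is a group of 10 heavy atoms (6 carbon, 3 nitrogen, 1 bromine; one five-membered aromatic ring with 1 hetero atom, one six-membered aromatic ring with 2 hetero atoms) in place of a group of 12 heavy atoms (6 carbon, 3 nitrogen, 2 fluorine, 1 chlorine; one five-membered aromatic ring with 2 hetero atoms, one six-membered aromatic ring with 1 hetero atom), on a saturated chain carbon bound to a double-bonded chain carbon, sitting on a saturated chain carbon bound to a double-bonded chain carbon. Since compound 2 has no number, no step size in this assay can be drawn between compound 2 and compound 4, in either direction. Compound 4 is expected to be a weak inhibitor, close to or weaker than compound 3, whose value 50000 nM is the sole anchor. The estimate for compound 4 is 80000 nM, with a range from 20000 nM to 300000 nM.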

Compound 4, half-maximal inhibitory concentration: 15000 nM
Estimate against measurement, compound 4: 5.3-fold (0.73 log units) above, and the stated range ends above it.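

In this assay compound 4 gives 15000 nM, but compound 2 has no number to set against it, so no step can be read between compound 2 and compound 4. The compounds shown leave open how much the group of 10 heavy atoms, taken alone on the shared core, changes antiproliferative activity.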